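This account rests on a few compounds, and the source may have more. Where it says the series, first, only, none or still open, it means among the compounds named here.

Measured so far in an ADME assay on NHDF cells (Homo sapiens) for antiproliferative activity, with a stated time of 72 h; a higher number here means a weaker inhibitor, a lower number a stronger inhibitor:

Compound 1 `CC(=O)Oc1ccc(/C=C/c2nc3ccccc3c(=O)[nH]2)c(OC(C)=O)c1`: > 25000 nM, a limit of the assay
Compound 2 `COc1ccccc1/C=C/c1nc(Nc2ccccc2Cl)c2ccccc2n1`: > 25000 nM, a limit of the assay

Neither compound has yielded a number, and the two share one ceiling: the limit of > 25000 nM in this assay, at which 2 of the 2 values shown sit. Compound 2 therefore stands at a limit and not at a measured potency. Going by the values given here, no step between measured compounds is available to serve as a guide.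

Compound 3 `COc1ccccc1/C=C/c1nc(Nc2ccc(O)cc2)c2ccccc2n1` has not yet been measured in this assay. It departs from compound 2 at a single place, with 4-hydroxyphenyl in place of 2-chlorophenyl on a nitrogen on an aromatic ring. The same change, cut one bond further out, reads (2-chlorophenyl)amino to (4-hydroxyphenyl)amino.

The expectation rests on little more than the limit of compound 2, > 25000 nM, so no change beyond the scatter is expected in either direction. The expected step is a number no higher from compound 2 to compound 3 (the limit leaves the size open). A further report of a limit is thought the likeliest outcome. The estimate for compound 3 is 25000 nM, with an expected range from 8000 nM to 60000 nM.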

Compound 3, half-maximal inhibitory concentration: 13800 nM
Compound 3: middle estimate off by 1.8-fold (0.26 log units), on the high side; the measured number falls inside the stated range.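

In this assay compound 3 is the first of the compounds shown to give a measured number, 13800 nM. A change of the group on this nitrogen can therefore bring the read-out down from the ceiling of the assay. Replacing 2-chlorophenyl with 4-hydroxyphenyl gives an at least 1.8-fold lower number from compound 2 to compound 3 (0.25 log units; that floor lies within the scatter), and this figure is only a floor that lies within the scatter, so the true size of the step may be larger but cannot be read from these two compounds. Even so, the ceiling remains the most common result among the compounds shown: the limit of > 25000 nM in this assay, at which 2 of the 3 values shown sit.

The two groups differ in both the chlorine and the hydroxyl, and the compounds shown do not separate the loss of the one from the arrival of the other. They also leave open how a plain phenyl, a methoxyphenyl or an aminophenyl on this nitrogen would read in this assay, and so whether the hydroxyl itself matters at all.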